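Chain extension in the aminofuranose series: compound 4

The source may hold more compounds than are shown below. What is called first, only, known or untested is meant among the compounds shown, and "the series" means these compounds.

Measured so far in a functional assay on PC-3 cells (Homo sapiens) for antiproliferative activity, read by MTT assay, with a stated time of 72 h; a higher number here means a weaker inhibitor, a lower number a stronger inhibitor:
compound 1 `CCCCCCCCCCCCNC[C@@H]1OC[C@H](N)[C@H]1O`, 2380 nM
compound 2 `CCCCCCCNC[C@@H]1OC[C@H](N)[C@H]1O`; here compound 2 gives only a limit, > 128000 nM
compound 3 `CCCCCCCCCNC[C@@H]1OC[C@H](N)[C@@H]1O`, 2030 nM

Compound 2 and compound 1 share a core and differ by pentyl in place of hydrogen on a saturated chain carbon, seven bonds along the chain from an amine nitrogen. This change gives an at least 53-fold lower number from compound 2 to compound 1 (1.73 log units; beyond the scatter); compound 2 sits at the limit of > 128000 nM in this assay, at which 1 of the 3 values shown sits, so the true size of that step is not known beyond its floor. The cores of compound 3 and compound 2 differ in a way that is not broken down here. Compound 3 and compound 1 stand within the scatter of each other in this assay.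

Compound 4 `CCCCCCCCCCCCCCNC[C@@H]1OC[C@H](N)[C@@H]1O` is not yet measured. It differs from compound 3 by pentyl in place of hydrogen on a saturated chain carbon, nine bonds along the chain from an amine nitrogen. This is the same kind of change as from compound 2 to compound 1, but the place differs: seven bonds along the chain from an amine nitrogen there, nine bonds here. Compound 3 already carries a longer chain, so compound 4 is expected to show a far smaller step than an at least 53-fold lower number from compound 2 to compound 1 (1.73 log units; beyond the scatter), estimated as a 1.4-fold lower number from compound 3 to compound 4 (0.13 log units; within the scatter). Compound 4 is estimated at 1500 nM, between 400 nM and 6000 nM.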

Compound 4, half-maximal inhibitory concentration: 1200 nM
Compound 4: middle estimate off by 1.3-fold (0.10 log units), on the high side; low and high end bracket the measured number.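

In this assay, pentyl in place of hydrogen on a saturated chain carbon, nine bonds along the chain from an amine nitrogen, gives a 1.7-fold lower number from compound 3 to compound 4 (0.23 log units; within the scatter), and this step on the core of compound 3 does not match the step on the core of compound 1: the same change on two cores in this assay, an at least 53-fold lower number (1.73 log units; beyond the scatter) from compound 2 to compound 1 and a 1.7-fold lower number (0.23 log units; within the scatter) from compound 3 to compound 4, at least 31-fold (1.50 log units) apart, beyond the scatter of two such steps

The two pairs differ in core, in the length of the starting chain and in the place of the change, and they do not show which of these accounts for the gap. Compound 2 gives > 128000 nM, which is a limit of the assay and not a number, leaving the earlier step with only a floor: the limit of > 128000 nM in this assay, at which 1 of the 4 values shown sits.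

Open, as far as these compounds go, is how the chain of compound 2 would read on the core of compound 3, a pairing that would set core against chain length directly. Also open, from the compounds shown here alone, is whether a longer chain than that of compound 4, or an amine or a carboxylic acid at the chain end, would move the number beyond the scatter.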